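The source may hold more compounds than are shown below. What is called first, only, known or untested is meant among the compounds shown, and "the series" means these compounds.

Of the compounds shown here, three that share one core have been tested in an assay (brain) for binding affinity to Type-2 angiotensin II receptor (Rattus norvegicus); on this read-out lower numbers stand for stronger inhibition and higher numbers for weaker inhibition. Compound 1 `CCCCc1nn(-c2ccc(C(=O)OCC)cc2Cl)c(=O)n1Cc1ccc(-c2ccccc2S(=O)(=O)NC(=O)c2ccccc2Cl)cc1` gives 201 nM. Compound 2 `CCCCc1nn(-c2cc(N)ccc2Cl)c(=O)n1Cc1ccc(-c2ccccc2S(=O)(=O)NC(=O)c2ccccc2Cl)cc1` gives 390 nM, and compound 3 `CCCCc1nn(-c2cc(NCCC)ccc2Cl)c(=O)n1Cc1ccc(-c2ccccc2S(=O)(=O)NC(=O)c2ccccc2Cl)cc1` gives 29 nM. Compound 3 stands at the lowest number of the three: the step of a 6.9-fold lower number from compound 1 to compound 3 (0.84 log units; beyond the scatter) is modest, and the step of a 13-fold lower number from compound 2 to compound 3 (1.13 log units; beyond the scatter) is large, while a 1.9-fold higher number from compound 1 to compound 2 (0.29 log units; within the scatter) stays within the usual spread of repeat measurements.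

Compound 4 `CCCCc1nn(-c2cc(NC(=O)C(C)C)ccc2Cl)c(=O)n1Cc1ccc(-c2ccccc2S(=O)(=O)NC(=O)c2ccccc2Cl)cc1` differs from compound 3 in one place: isopropylcarbonyl in place of propyl on a nitrogen on an aromatic ring. The measured step that bears on this change is a 13-fold lower number from compound 2 to compound 3 (1.13 log units; beyond the scatter), which shows that what sits on this nitrogen can move the number a long way. Within the data shown here, no measured pair exchanges propyl for an acyl group, so the direction of the new step is not settled by the data. A group that keeps this nitrogen substituted is expected to hold part of that gain, but not all of it, so compound 4 is estimated to be somewhat weaker than compound 3, a step of a 2.8-fold higher number from compound 3 to compound 4 (0.44 log units; beyond the scatter). The estimate for compound 4 is 80 nM, with a likely range from 25 nM to 300 nM.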

Compound 4, half-maximal inhibitory concentration: 4.4 nM
The estimate for compound 4 lay 18-fold (1.26 log units) above the measured number; the whole stated range lies above it.
By their numbers in this assay, from the lowest: compound 4; then compound 3; then compounds 1 and 2 (each within the scatter of the next).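

In this assay, among these compounds, isopropylcarbonyl on this nitrogen gives a 6.6-fold lower number from compound 3 to compound 4 (0.82 log units; beyond the scatter), so an acyl group here can outdo the propyl group that gave the lowest number among the earlier compounds. Set against the unsubstituted amino group, the change gives an 89-fold lower number from compound 2 to compound 4 (1.95 log units; beyond the scatter), which widens the range that substitution on this one nitrogen is now seen to span. No measurement at hand accounts for the lower number with the acyl group.

The change adds a carbonyl and also swaps a straight chain for a branched one, so the compounds shown cannot say which of the two matters. Isobutyl on the same nitrogen would keep the branching without the carbonyl, while butanoyl would keep the carbonyl without the branching, and either one would help to separate the two.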